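Swapping ethyl for tert-butoxycarbonyl on the azetidine nitrogen

This account rests on a few compounds, and the source may have more. Where it says the series, first, only, none or still open, it means among the compounds named here.

Compound 3 `CCN1CC(NC(=O)[C@@H]2CCCN(S(=O)(=O)c3ccc(S(=O)(=O)N(CC)CC)cc3)C2)C1` sits at the floor of the series: in a functional assay on BXPC-3 cells (Homo sapiens) for inhibition, read by MTT assay, with a stated time of 7 days (a lower number here means a stronger inhibitor, a higher number a weaker inhibitor), compound 3 gives only a limit, > 30000 nM (the limit of > 30000 nM in this assay, at which 1 of the 3 values shown sits). Compound 1 `CCN(CC)S(=O)(=O)c1ccc(S(=O)(=O)N2CCC[C@@H](C(=O)N[C@@H]3CCN(C(=O)OC(C)(C)C)C3)C2)cc1` gives 400 nM, and compound 2 `CCN(CC)S(=O)(=O)c1ccc(S(=O)(=O)N2CCC[C@@H](C(=O)NC3CN(C(=O)C4CC4)C3)C2)cc1` gives 18500 nM. The new compound 4 `CCN(CC)S(=O)(=O)c1ccc(S(=O)(=O)N2CCC[C@@H](C(=O)NC3CN(C(=O)OC(C)(C)C)C3)C2)cc1` differs from compound 3 by tert-butoxycarbonyl in place of ethyl on an amine nitrogen in a ring. Among the compounds with values here, two measured steps bear on this. The step of an at least 75-fold higher number from compound 1 to compound 3 (1.87 log units; beyond the scatter) was large, while a 46-fold higher number from compound 1 to compound 2 (1.67 log units; beyond the scatter) was also large, and the step of an at least 1.6-fold higher number from compound 2 to compound 3 (0.20 log units; that floor lies within the scatter) has a floor that lies within the scatter. Compound 4 carries a carbonyl-type group on that nitrogen, as compound 2 does, so compound 4 is expected to land near compound 2 rather than at the limit, giving a step of about an at least 2.5-fold lower number from compound 3 to compound 4 (0.39 log units; beyond the scatter). For compound 4 the estimate is 12000 nM, within 3000 nM to 40000 nM.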

Compound 4, half-maximal inhibitory concentration: 1800 nM
Estimate against measurement, compound 4: 6.7-fold (0.82 log units) above; measured number below the stated range.
By their numbers in this assay, from the lowest: compound 1; then compound 4; then compound 2. At a limit, above all of these: compound 3.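

Compound 3 gives only a limit: the limit of > 30000 nM in this assay, at which 1 of the 4 values shown sits. On the amine nitrogen in the ring, tert-butoxycarbonyl in place of ethyl gives an at least 16-fold lower number from compound 3 to compound 4 (1.22 log units; beyond the scatter), and tert-butoxy in place of cyclopropyl on the carbonyl carbon gives a 10-fold lower number from compound 2 to compound 4 (1.01 log units; beyond the scatter), so a carbonyl alone does not set the result. With tert-butoxycarbonyl kept, the change of ring gives a 4.5-fold higher number from compound 1 to compound 4 (0.65 log units; beyond the scatter), so the ring is not the whole of the distance between these compounds.

From the compounds shown here alone, what a free amine or a methoxycarbonyl group on that nitrogen would give remains open.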